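A few compounds are considered here, and "the series" means these few. Any claim that something is new, unique, unknown or untested is made for them only; others in the source may bear on it.

Measured so far in a functional assay on NCI/ADR-RES cells (Homo sapiens) for inhibition, read by sulforhodamine B assay, with a stated time of 48 h; a higher number here means a weaker inhibitor of growth, a lower number a stronger inhibitor of growth:
Compound 1 `CCOC(=O)C1=C(C)NC(=O)NC1c1ccc(SC)cc1` gives 2.7 ug/mL
Compound 2 `CCOC(=O)C1=C(C)NC(=S)NC1C1CCCCC1` gives 24.1 ug/mL
Compound 3 `CCOC(=O)C1=C(C)NC(=S)NC1c1ccc(O)c(O)c1` gives 24.3 ug/mL

Compound 1 has the lowest number of the three, and the gaps up to compound 2 and compound 3 both lie beyond the scatter, so it is the strongest growth inhibitor here. Compound 4 `CCOC(=O)C1=C(C)NC(=O)NC1c1ccc(O)cc1` keeps the core of compound 1 and changes one group: hydroxy in place of methylsulfanyl on an aromatic carbon with hydroxy in place of methylsulfanyl on an aromatic carbon. For the measured compounds named here, no measured pair shows this swap alone. Compound 3, which also carries hydroxy on its aromatic ring, gives 24.3 ug/mL and offers only a loose hint. The expected change is a 3.3-fold higher number from compound 1 to compound 4 (0.52 log units; beyond the scatter) toward weaker inhibition in this assay and beyond the scatter. The estimate for compound 4 is 9 ug/mL and the expected range runs from 2.5 ug/mL to 35 ug/mL.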

Compound 4, concentration for 50% growth inhibition: 3.2 ug/mL
Beside the measured number, compound 4's estimate is 2.8-fold (0.45 log units) above it; the range from low to high includes it.
By their numbers in this assay, from the lowest: compounds 1 and 4 (each within the scatter of the next); then compounds 2 and 3 (each within the scatter of the next).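

In this assay, for the compounds shown here, hydroxy in place of methylsulfanyl on an aromatic carbon gives a 1.2-fold higher number from compound 1 to compound 4 (0.07 log units; within the scatter), the first step that isolates a single change at this position. The two groups differ in heavy atoms and hydrogen-bond donors, yet this assay cannot tell them apart here. Nothing measured here gives a reason for this result.

From the compounds shown here alone, it remains open whether a methoxy group, an amine or a carboxylic acid at this position would also match methylsulfanyl. Also open, going by these compounds, is whether the same swap would read alike in compounds carrying sulfur instead of the carbonyl oxygen, such as compound 3.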